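Amide aryl replacement in the catechol ether series

The compounds below may be only part of what the source reports. "The series", "measured", "known", "first", "only" and "open" are said of these compounds alone.

Compound 1 `COc1ccc(C(=O)Nc2c(F)cccc2F)cc1OC1CCCC1` gives 70 nM in an assay on isolated protein for inhibition of phosphodiesterase 4A (Sus scrofa); on this read-out higher numbers stand for weaker inhibition and lower numbers for stronger inhibition. Within the data shown here, compound 2 `COc1ccc(C(=O)Nc2c(F)cccc2Cl)cc1OC1CCCC1` gives 240 nM in this assay, the higher of the two numbers measured so far; the only step in the set, a 3.4-fold higher number from compound 1 to compound 2 (0.54 log units; beyond the scatter), records a weakening of inhibition. Compound 3 `COc1ccc(C(=O)Nc2ccccc2O)cc1OC1CCCC1` is obtained from compound 2 by 2-hydroxyphenyl in place of 2-chloro-6-fluorophenyl on an amide-type nitrogen. Among the measured compounds shown here, no measured step bears directly on this change: the single step available swaps one halogen for another, whereas the change to compound 3 removes both halogens and brings in a group with one hydrogen-bond donor and one hydrogen-bond acceptor. The expectation therefore rests on weak footing, with wide uncertainty in either direction. On balance, compound 3 is expected to give 300 nM in this assay, within a range of 80 nM to 1200 nM, corresponding to an estimated step of a 1.3-fold higher number from compound 2 to compound 3 (0.10 log units; within the scatter).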

Compound 3, half-maximal inhibitory concentration: 1300 nM
Estimate against measurement, compound 3: 4.3-fold (0.64 log units) below; measured number above the stated range.
By their numbers in this assay, from the lowest: compound 1; then compound 2; then compound 3.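

In this assay, 2-hydroxyphenyl in place of 2-chloro-6-fluorophenyl on the amide-type nitrogen weakens inhibition, with a 5.4-fold higher number from compound 2 to compound 3 (0.73 log units; beyond the scatter), and in place of 2,6-difluorophenyl it gives a large step, with a 19-fold higher number from compound 1 to compound 3 (1.27 log units; beyond the scatter). Compound 3 is therefore the weakest of the three, and this position responds to more than the swap of one halogen for another. No evidence bearing on the reason for this loss is available.

The compounds shown do not separate the loss of the halogens from the entry of the hydroxyl group, as compound 3 carries both changes at once. Going by these compounds, whether a methoxy group or an amine on this aryl ring would behave like the hydroxyl group or like the halogens remains open.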